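Reading a cell toxicity limit across a ketone swap

The source may hold more compounds than are shown below. What is called first, only, known or untested is meant among the compounds shown, and "the series" means these compounds.

- Compound 1 `O=C(c1ccc2c(c1)OCCO2)C1CCN(Cc2coc(-c3ccc(F)cc3)n2)CC1` in an ADME assay on HEK293 cells (Homo sapiens) for cytotoxicity, read by MTT assay, with a stated time of 36 h; on this read-out lower numbers stand for stronger inhibition and higher numbers for weaker inhibition: > 150 ug/mL
- Compound 2 `CC(C)(C)c1ccc(-c2nc(CN3CCC(C(=O)c4ccc5c(c4)OCCO5)CC3)co2)cc1` in this assay: > 150 ug/mL

The result for compound 1 is a limit and not a number, given as > 150 ug/mL. Both measured compounds share one reading, (the limit of > 150 ug/mL in this assay, at which 2 of the 2 values shown sit). The compound to follow is compound 3 `Cc1ccc(C(=O)C2CCN(Cc3coc(-c4ccc(F)cc4)n3)CC2)cc1`, which differs from compound 1 as follows: 4-methylphenyl in place of 2,3-dihydro-1,4-benzodioxin-6-yl on a carbonyl carbon. Here 4-methylphenyl stands in place of 2,3-dihydro-1,4-benzodioxin-6-yl on a carbonyl carbon.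

For the measured compounds named here, only one measured step is available, a step that the two limits leave unreadable from compound 1 to compound 2. That step has no readable size, and it concerns tert-butyl in place of fluoro on an aromatic carbon, not the group exchanged here. In this assay no step beyond the scatter is therefore expected, in either direction. The estimated step is a step that the limit leaves unreadable from compound 1 to compound 3. For compound 3 the estimate is 200 ug/mL, with an expected range of 120 ug/mL to 400 ug/mL.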

Compound 3, half-maximal inhibitory concentration: > 150 ug/mL
Compound 3 gave a limit, no number (the forecaster's own chance of this, stated with the estimate: 80%); the middle value does not contradict the limit.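

In this assay compound 1 and compound 3 both give only a limit, so no step can be read between them, since all the compounds shown share one reading: the limit of > 150 ug/mL in this assay, at which 3 of the 3 values shown sit. The compounds shown leave open whether either group exchange changes cytotoxicity at all, and by how much.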